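A few compounds are considered here, and "the series" means these few. Any claim that something is new, unique, unknown or untested is made for them only; others in the source may bear on it.

Working notes on the series, the step from compound 3 to compound 4.

Three compounds share the core of compound 1 `Cc1cc(C(=O)O)nn1Cc1cc(Br)ccc1OCc1ccccc1` and differ at one carbon of the five-membered ring. In a functional assay on CHO-K1 cells for antagonist activity at prostaglandin E2 receptor EP1 subtype (Homo sapiens), read by FLIPR (a higher number here means a weaker inhibitor, a lower number a stronger inhibitor), compound 1 gives 15.1 nM. Compound 2 `CC(=O)Nc1cc(C(=O)O)nn1Cc1cc(Br)ccc1OCc1ccccc1` carries acetamido there; in this assay compound 2 reaches only the limit < 2000 nM, and the reading is a limit, not a number. The step that the limit leaves unreadable from compound 1 to compound 2 is therefore not readable in size, as noted for (the limit of < 2000 nM in this assay, at which 1 of the 3 values shown sits). Compound 3 `O=C(O)c1nn(Cc2cc(Br)ccc2OCc2ccccc2)cc1F` carries fluoro; in this assay compound 3 gives 692 nM, the highest of the two numbers shown, and the gap to compound 1 lies beyond the scatter.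

Compound 4 `O=C(O)c1nn(Cc2cc(Br)ccc2OCc2ccccc2)cc1C(F)(F)F` differs from compound 3 by trifluoromethyl in place of fluoro on an aromatic carbon. Going by the values given here, no measured step describes this exchange; the one readable step, from methyl to fluoro between compound 1 and compound 3, points only to the ring carbon being sensitive to what sits on it. Compound 4 is estimated at 400 nM, within 100 nM to 2000 nM, which means an expected step of a 1.7-fold lower number from compound 3 to compound 4 (0.24 log units; within the scatter).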

Compound 4, inhibition constant: < 2000 nM
Compound 4: a limit, no number (the forecaster's own chance of this, stated with the estimate: 10%); the middle value does not contradict the limit.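

In this assay compound 4 gives < 2000 nM as a limit and not a number, so the step from compound 3 to compound 4 cannot be read in size: the limit of < 2000 nM in this assay, at which 2 of the 4 values shown sit. The compounds shown leave open how trifluoromethyl on this aromatic carbon stands against fluoro and methyl.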